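The source may report more compounds than this note shows. Statements on the series, on what has been measured and on what is new or still open speak of the compounds shown alone.

The study gathers three compounds on a shared core, compound 1 `Cc1cc(NC(=O)Nc2ccccc2OC(F)(F)F)c2ccccc2n1`, compound 2 `CSc1ccc(NC(=O)Nc2cc(C)nc3ccccc23)cc1` and compound 3 `Cc1cc(NC(=O)Nc2cccc(C(N)=O)c2)c2ccccc2n1`, all tested in an ADME assay on Raji cells (Homo sapiens) for cytotoxicity, with a stated time of 72 h; a lower number here means that less compound is needed, a higher number that more compound is needed for the effect. Compound 1 reaches only a limit of the assay, giving > 25000 nM. Compound 2 likewise returns a limit, > 25000 nM. Compound 3 too stops at a limit, > 25000 nM. Every value so far therefore sits at the limit of > 25000 nM in this assay, at which 3 of the 3 values shown sit, so compound 1 stands nowhere apart from its neighbours on the numbers shown. Compound 4 `Cc1cc(NC(=O)Nc2ccccc2F)c2ccccc2n1` differs from compound 1 by fluoro in place of trifluoromethoxy on an aromatic carbon. Within the data shown here, with no measured step to go by, the estimate amounts to a step that the limit leaves unreadable from compound 1 to compound 4, which is no change beyond the scatter. Compound 4 is expected to give 40000 nM in this assay, within a range from 15000 nM to 150000 nM.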

Compound 4, half-maximal effective concentration: > 25000 nM
Compound 4: no number, only a limit; the forecaster's own chance of this, stated with the estimate: 85%; the middle value does not contradict the limit.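

Compound 1 and compound 4 both return only a limit, so no step can be read between them: the limit of > 25000 nM in this assay, at which 4 of the 4 values shown sit. The compounds shown leave open how the groups on the shared core compare in this assay.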